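The source may report more compounds than this note shows. Statements on the series, on what has been measured and on what is new or still open speak of the compounds shown alone.

Three compounds here share one core, and the series begins with compound 1 `COc1ccc(-c2cc3ccccc3nc2C=O)cc1`. In a functional assay on A549 cells (Homo sapiens) for antiproliferative activity, read by XTT assay, with a stated time of 72 h (a lower number here means a stronger inhibitor, a higher number a weaker inhibitor), compound 1 gives only a limit of the assay, > 10000 nM. Compound 2 `COc1ccc(-c2cc3ccccc3nc2/C=C/C(=O)c2ccc(OC)c(OC)c2)cc1` carries a 3,4-dimethoxyphenyl group on the carbonyl carbon, and in this assay compound 2 gives 8860 nM. Compound 3 `COc1ccc(-c2cc3ccccc3nc2/C=C/C(=O)c2ccc(N)cc2)cc1` replaces that group with 4-aminophenyl, and in this assay compound 3 gives 7530 nM. Among the two numbers shown, compound 3 has the lowest, yet the step of a 1.2-fold lower number from compound 2 to compound 3 (0.07 log units; within the scatter) leaves compound 2 and compound 3 within the scatter of each other.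

Compound 4 `COc1ccc(-c2cc3ccccc3nc2/C=C/C(=O)c2c[nH]c3ccccc23)cc1` is not yet measured. Its change from compound 3 is 1H-indol-3-yl in place of 4-aminophenyl on a carbonyl carbon. Among the measured compounds shown here, the only measured step that bears on it is the exchange of one aryl group on the same carbonyl carbon, a 1.2-fold lower number from compound 2 to compound 3 (0.07 log units; within the scatter), which stayed within the scatter. On that basis the step of a 1.1-fold lower number from compound 3 to compound 4 (0.03 log units; within the scatter) is expected to be small. Compound 4 is therefore estimated at 7000 nM, somewhere between 2500 nM and 20000 nM.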

Compound 4, half-maximal inhibitory concentration: > 10000 nM
Compound 4: a limit, no number; the forecaster's own chance of this, stated with the estimate: 30%; at least 1.4-fold (0.15 log units) between middle value and limit.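

With 1H-indol-3-yl on the carbonyl carbon, this position gives a limit of the assay rather than a number for the first time among the chalcone-type compounds shown, so this exchange of aryl groups cannot be sized exactly. Only floors can be read: an at least 1.3-fold higher number from compound 3 to compound 4 (0.12 log units; that floor lies within the scatter) and an at least 1.1-fold higher number from compound 2 to compound 4 (0.05 log units; that floor lies within the scatter) are all the data give, and since both floors lie within the scatter, a real loss of activity is possible but not shown. The true size of the step stays hidden because the value stops at the end of the measured range: the limit of > 10000 nM in this assay, at which 2 of the 4 values shown sit.

As far as these compounds go, how far compound 4 really lies past that limit remains open. From the compounds shown here alone, it is also open whether a smaller group on the same carbonyl carbon, such as methyl, or a phenyl ring carrying a carboxylic acid, would move the number beyond the scatter.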